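The source may hold more compounds than are shown below. What is called first, only, known or untested is meant among the compounds shown, and "the series" means these compounds.

Measured compounds:
- compound 1, `N=S1(=O)c2ccccc2C(=O)N1c1ccccc1` — in an ADME assay on Caco-2 cells (Homo sapiens) for permeability (on this read-out lower numbers stand for lower permeability and higher numbers for higher permeability), compound 1 is reported as "not determined" (no result reported)
- compound 2, `CCN=S1(=O)NC(=O)c2ccccc21` — in this assay compound 2 gives 26.8 10^-6 cm/s
- compound 3, `CCNC1=NS(=O)(=O)c2ccccc21` — in this assay compound 3 gives 29.3 10^-6 cm/s

Compound 1 stands nowhere on the numbers shown: no value was reported for it in this assay, so it cannot be placed against compound 2 or compound 3. The values of compound 2 and compound 3 lie within the usual scatter of each other, and nothing is said here about order between them.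

Compound 4, `CCN1C(=O)c2ccccc2S1(=N)=O`, is not yet measured. It differs from compound 1 in one place: ethyl in place of phenyl on an amide-type nitrogen in a ring. As far as these compounds go, without a number for compound 1, neither the size nor the direction of the step from compound 1 to compound 4 in this assay can be stated; the step itself is unknown.

The estimate for compound 4 therefore rests on the two ethyl-bearing compounds that were measured. Compound 4 is expected to give about 27 10^-6 cm/s in this assay, with a range from 14 10^-6 cm/s to 45 10^-6 cm/s, because compound 2 gives 26.8 10^-6 cm/s and compound 3 gives 29.3 10^-6 cm/s in the same assay.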

Compound 4, apparent permeability in the Caco-2 assay: 92 10^-6 cm/s
Compound 4: the middle estimate sits 3.4-fold (0.53 log units) below what was measured; measured number outside the range, above it.
By their numbers in the Caco-2 assay, from the lowest: compounds 2 and 3 (each within the scatter of the next); then compound 4.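

Among these compounds, no step from compound 1 to compound 4 can be read in the Caco-2 assay: compound 1 has no number there. In a physicochemical assay for lipophilicity, at pH 7.4 (a higher number here means a more lipophilic compound, a lower number a more polar compound), compound 1 gives 1.3 and compound 4 gives 0.7. As far as these compounds go, what ethyl in place of phenyl does in the Caco-2 assay stays open.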